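The source may report more compounds than this note shows. Statements on the series, on what has been measured and on what is new or still open speak of the compounds shown alone.

Working notes on the series. In a functional assay, read by fluorescence and spectrophotometry, with a stated time of 1 h (on this read-out higher numbers stand for an effect only at larger amounts of compound and lower numbers for an effect already at smaller amounts), compound 1 (`CCCCCCCCCCCCS(=O)(=O)/C=C/c1ccc(O)c(O)c1`) gives 8500 nM, compound 2 (`C=CCCCCCCCS(=O)(=O)/C=C/c1ccc(O)c(O)c1`) gives 6900 nM and compound 3 (`O=S(=O)(/C=C/c1ccc(O)c(O)c1)CCC1CCCC1`) gives 6800 nM. Compound 3 therefore stands within the usual scatter of both other compounds, and the three values show no separation.

The next change leads to compound 4 (`CCCCCCCCS(=O)(=O)/C=C/c1ccc(O)c(O)c1`). Hexyl replaces cyclopentyl on a saturated chain carbon, two bonds along the chain from a sulfonyl sulfur: hexyl in place of cyclopentyl on a saturated chain carbon, two bonds along the chain from a sulfonyl sulfur.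

Among the compounds with values here, two measured steps bear on this change. The closer precedent is a 1.0-fold lower number from compound 2 to compound 3 (0.01 log units; within the scatter), which exchanges an open chain for cyclopentyl at this same place, the reverse sense of the present change. The other is a 1.2-fold lower number from compound 1 to compound 2 (0.09 log units; within the scatter), a change further out along the chain. Both steps stay within the scatter, so neither gives a direction for the new step. Only these three values support the expectation, and compound 4 has not yet been measured in this assay.

The expected outcome is no step beyond the scatter, and the estimated step is a 1.1-fold higher number from compound 3 to compound 4 (0.02 log units; within the scatter). For compound 4 the estimated value is 7200 nM, with an expected range of 4000 nM to 13000 nM.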

Compound 4, half-maximal effective concentration: 6400 nM
Estimate against measurement, compound 4: 1.1-fold (0.05 log units) above; measured number inside the range.
By their numbers in this assay, from the lowest: compounds 4, 3, 2 and 1 (each within the scatter of the next).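

The hexyl of compound 4 and the cyclopentyl of compound 3 give no separation in this assay at this place, on a saturated chain carbon, two bonds along the chain from a sulfonyl sulfur, with a 1.1-fold lower number from compound 3 to compound 4 (0.03 log units; within the scatter); the ring and the open chain are thus not told apart here, now in the direct exchange of cyclopentyl for a saturated chain as well as in the earlier exchange involving hept-6-en-1-yl. Compound 4 also adds two comparisons further out along the chain, with a 1.1-fold lower number from compound 2 to compound 4 (0.03 log units; within the scatter) for methyl in place of vinyl and a 1.3-fold lower number from compound 1 to compound 4 (0.12 log units; within the scatter) for hydrogen in place of butyl, and neither step leaves the scatter, so all four compounds remain unseparated. No available evidence bears on why these changes leave the read-out within the scatter.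

The groups shown at this place are all built of carbon and hydrogen only, so the effect of an amine or a carboxylic acid on the chain remains open. The compounds shown also leave open how a much shorter chain would read, and what changes to the shared core would do.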